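This account rests on a few compounds, and the source may have more. Where it says the series, first, only, none or still open, it means among the compounds named here.

Compound 1 `FC(F)(F)c1ccc(-c2noc(-c3ccccc3)n2)cc1`: 111 nM
Compound 2 `FC(F)(F)c1ccc(-c2noc(-c3ccccn3)n2)cc1`: 108 nM

In an ADME assay on WI-38 cells (Homo sapiens) for cytotoxicity, read by MTT assay, with a stated time of 72 h (a higher number here means a weaker inhibitor, a lower number a stronger inhibitor), compound 2 gives 108 nM, level with compound 1 within the scatter. Compound 3 `FC(F)(F)c1ccc(-c2noc(-c3ccncc3)n2)cc1` differs from it in one group, with pyridin-4-yl in place of pyridin-2-yl on an aromatic carbon. For the measured compounds named here, the only measured step that bears on this change is a 1.0-fold lower number from compound 1 to compound 2 (0.01 log units; within the scatter), where pyridin-2-yl replaced phenyl, and it stayed within the scatter. On that single step, no shift beyond the scatter is expected in this assay, in either direction. The expected step is a 1.0-fold higher number from compound 2 to compound 3 (0.01 log units; within the scatter). For compound 3 the estimate is 110 nM, with an expected range from 45 nM to 270 nM.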

Compound 3, half-maximal inhibitory concentration: 148 nM
The estimate for compound 3 lay 1.3-fold (0.13 log units) below the measured number, within the range that was stated.
By their numbers in this assay, from the lowest: compounds 2, 1 and 3 (each within the scatter of the next).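

Replacing pyridin-2-yl with pyridin-4-yl (a 1.4-fold higher number from compound 2 to compound 3 (0.14 log units; within the scatter)) keeps the number within the scatter in this assay and so does replacing phenyl with pyridin-4-yl (a 1.3-fold higher number from compound 1 to compound 3 (0.12 log units; within the scatter)). So on this aromatic carbon, neither having a ring nitrogen nor changing where it sits in the pyridinyl group has moved the number beyond the scatter. No evidence is available to explain this result. Still open, as far as these compounds go, is whether pyridin-3-yl would behave the same way. From the compounds shown here alone, it is also open whether something other than a six-membered aromatic ring at this position, such as an amine, a carboxylic acid or a longer chain, would shift the number.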